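A few compounds are considered here, and "the series" means these few. Any claim that something is new, unique, unknown or untested is made for them only; others in the source may bear on it.

Measured compounds:
Compound 1, `CN(C(=S)SCc1ccc(C(=O)Nc2ccccc2N)cc1)c1cccnc1`, in a functional assay on A-375 cells (Homo sapiens) for antiproliferative activity, read by CCK-8 assay, with a stated time of 72 h, tested at 8 uM (a higher number here means a stronger effect of the compound at the concentration tested, a lower number a weaker effect), gives 87.7%.
Compound 2, `CCN(Cc1ccncc1)C(=S)SCc1ccc(C(=O)Nc2ccccc2N)cc1`, in this assay gives 86.2%.

Going by the values given here, compound 2 is one of only two numbers so far, and the only measured step is a number 1.5 percentage points lower from compound 1 to compound 2 (within the scatter); on these numbers the two compounds cannot be told apart. Among the compounds with values here, the single change between them sits on the thiocarbonyl carbon of the shared core, where the amino group was exchanged.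

Compound 3, `CC1CCN(C(=S)SCc2ccc(C(=O)Nc3ccccc3N)cc2)CC1`, has not yet been measured. It differs from compound 2 by 4-methylpiperidin-1-yl in place of ethyl((pyridin-4-yl)methyl)amino on a thiocarbonyl carbon. Within the data shown here, this is again an exchange of the amino group on the thiocarbonyl carbon, so the only measured step that bears on it is the one from compound 1 to compound 2, which stayed within the scatter. Among the measured compounds shown here, that step suggests the read-out tolerates such an exchange, though the entering non-aromatic ring is of a kind no measured compound covers. The expectation for compound 3 in this assay is therefore a step of about a number 2.2 percentage points lower from compound 2 to compound 3 (within the scatter), none beyond the scatter. Compound 3 is estimated at 84%, with a range from 66% to 94%.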

Compound 3, a percentage reported as inhibition, at one concentration (the size of the read-out at that concentration, not a potency): 87.4%
Estimate against measurement, compound 3: 3.4 percentage points below; low and high end bracket the measured number.
By their numbers in this assay, from the lowest: compounds 2, 3 and 1 (each within the scatter of the next).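

Until now, each amino group on the thiocarbonyl carbon carried a pyridine ring, so the data could not show whether the read-out in this assay depended on having such an aromatic ring there. Exchanging ethyl((pyridin-4-yl)methyl)amino for 4-methylpiperidin-1-yl gives a number 1.2 percentage points higher from compound 2 to compound 3 (within the scatter), and exchanging methyl(pyridin-3-yl)amino for the same group gives a number 0.3 percentage points lower from compound 1 to compound 3 (within the scatter), so at this single test concentration the read-out is matched by a six-membered non-aromatic ring with no hydrogen-bond acceptor, as well as by either pyridine-bearing group. Nothing available explains why the three compounds cannot be told apart at this position.

All three numbers come from one concentration, so they report the size of the effect there and not potency, and real differences between the compounds could be hidden at lower concentrations. On these data alone, it also remains open whether this tolerance extends to groups of a different kind on the thiocarbonyl carbon, such as morpholin-4-yl, a piperidine ring bearing a carboxylic acid, or an open-chain diethylamino group.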